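Moving the Bromine Around the Sulfonyl Ring

The source may hold more compounds than are shown below. What is called first, only, known or untested is meant among the compounds shown, and "the series" means these compounds.

Compound 2 `CC(=O)Nc1nc(-c2cccc(NS(=O)(=O)c3ccc(Br)cc3)c2)cs1` has the higher of the two numbers in a functional assay on A-375 cells (Homo sapiens) for antiproliferative activity, read by trypan blue exclusion, with a stated time of 48 h, tested at 10 uM (a lower number here means a stronger effect, a higher number a weaker effect of the compound at the concentration tested), giving 25.6%. Compound 1 `CCCCCCC#Cc1ccc(S(=O)(=O)Nc2cccc(-c3csc(NC(C)=O)n3)c2)cc1` gives 5.8% in this assay, and the step of a number 19.8 percentage points higher from compound 1 to compound 2 (beyond the scatter) came with bromo in place of oct-1-yn-1-yl on an aromatic carbon. Compound 3 `CC(=O)Nc1nc(-c2cccc(NS(=O)(=O)c3cccc(Br)c3)c2)cs1` differs from compound 2 by 3-bromophenyl in place of 4-bromophenyl on a sulfonyl sulfur. Within the data shown here, no measured step shows what exchanging 4-bromophenyl for 3-bromophenyl does, so the one known step offers no guide, and the expected step is a number 1.4 percentage points higher from compound 2 to compound 3 (within the scatter), nothing beyond the scatter. For compound 3 the estimate in this assay is 27%, ranging from 8% to 55%.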

Compound 3, a percentage reported as activity, at one concentration (the size of the read-out at that concentration, not a potency): 36%
Compound 3: middle estimate off by 9 percentage points, on the low side, within the range that was stated.
By their numbers in this assay, from the lowest: compound 1; then compound 2; then compound 3.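

Where the bromine sits on the ring attached to the sulfonyl sulfur makes a measurable difference. With the same atoms joined differently, 3-bromophenyl in place of 4-bromophenyl gives a number 10.4 percentage points higher from compound 2 to compound 3 (beyond the scatter) in this assay, so compound 3 has the weaker effect at the concentration tested. Nothing available explains this difference.

Still open, from the compounds shown here alone, is whether an amine or a carboxylic acid in place of the bromine would give a stronger or weaker effect. Also open, going by these compounds, is whether the oct-1-yn-1-yl group would respond to the same shift as bromine does.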